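Series notes: an ether in place of the secondary amine

The source may hold more compounds than are shown below. What is called first, only, known or untested is meant among the compounds shown, and "the series" means these compounds.

Of the compounds shown here, three on the shared core have been measured in an in vitro assay on 293-EBNA cells for binding affinity to corticotropin-releasing factor receptor 1 (Homo sapiens); on this read-out higher numbers stand for weaker inhibition and lower numbers for stronger inhibition. Compound 1 `CCCCN(CC)c1nc(C)nc2c1ncn2-c1ccc(C(C)C)cc1Br` gives 4.3 nM. Compound 2 `CCCCN(CCCC)c1nc(C)nc2c1ncn2-c1ccc(C(C)C)cc1Br` gives 6.1 nM. Compound 3 `CCCC(CC)Nc1nc(C)nc2c1ncn2-c1ccc(C(C)C)cc1Br` gives 4.4 nM, which stands second highest of the three numbers, though all three sit within the scatter of one another; its nearest neighbour is compound 1 and its furthest compound 2. The three steps among them, a 1.4-fold higher number from compound 1 to compound 2 (0.15 log units; within the scatter), a 1.0-fold higher number from compound 1 to compound 3 (0.01 log units; within the scatter) and a 1.4-fold lower number from compound 2 to compound 3 (0.14 log units; within the scatter), are all within the scatter.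

Compound 4 `CCC(CC)Oc1nc(C)nc2c1ncn2-c1ccc(C(C)C)cc1Br` changes the attachment atom: (pentan-3-yl)oxy in place of (1-ethylbutyl)amino on an aromatic carbon. Within the data shown here, none of the measured steps bears directly on this change, since each of them varies only the carbon chains on the nitrogen and keeps the nitrogen itself; they show only that such variation, a 1.0-fold higher number from compound 1 to compound 3 (0.01 log units; within the scatter) for example, leaves the number essentially unchanged. Going by these compounds, the exchange of the nitrogen for oxygen, with the loss of the one hydrogen-bond donor, is untested in this set. For compound 4 a modest weakening is expected, a 2.7-fold higher number from compound 3 to compound 4 (0.44 log units; beyond the scatter), with wide uncertainty. Compound 4 is estimated at 12 nM, within 3 nM to 50 nM.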

Compound 4, inhibition constant: 3.5 nM
Beside the measured number, compound 4's estimate is 3.4-fold (0.54 log units) above it; low and high end bracket the measured number.
By their numbers in this assay, from the lowest: compounds 4, 1, 3 and 2 (each within the scatter of the next).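

In this assay, the attachment atom at this aromatic carbon can change from nitrogen to oxygen, with the hydrogen-bond donor gone and the chain shorter, without a step beyond the scatter: a 1.3-fold lower number from compound 3 to compound 4 (0.10 log units; within the scatter). The ether also stays within the scatter of the two disubstituted amines, with (pentan-3-yl)oxy in place of dibutylamino giving a 1.7-fold lower number from compound 2 to compound 4 (0.24 log units; within the scatter) and in place of butyl(ethyl)amino giving a 1.2-fold lower number from compound 1 to compound 4 (0.09 log units; within the scatter), so across these four compounds a donor on the attached group is not required for numbers in this range. Nothing available explains this tolerance.

Going by these compounds, since the chain differs along with the attachment atom, the separate contribution of each remains open. Also open, on these data alone, is whether a thioether, or a longer chain such as (heptan-4-yl)oxy, would stay within the same range.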